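Thiadiazolyl for cyanomethylpyrazolyl on the aryl-amine nitrogen

The source may report more compounds than this note shows. Statements on the series, on what has been measured and on what is new or still open speak of the compounds shown alone.

Among the measured compounds shown here, the series shares one core; the three measured members are compound 1 `COc1cccc(CNC(=O)c2cccc(C(C)Oc3cccnc3Nc3cnn(C)c3)c2)c1`, compound 2 `Cc1ccc(CNC(=O)c2cccc(C(C)Oc3cccnc3Nc3nccs3)c2)cc1` and compound 3 `Cc1ccc(CNC(=O)c2cccc(C(C)Oc3cccnc3Nc3cnn(CC#N)c3)c2)cc1`, all read in a functional assay on HCC78 cells (Homo sapiens) for antiproliferative activity, read by MTT assay, with a stated time of 48 h; on this read-out lower numbers stand for stronger inhibition and higher numbers for weaker inhibition. Compound 1 gives 78600 nM, compound 2 gives 27100 nM and compound 3 gives 57400 nM. Compound 3 therefore stands second highest of the three numbers: its gap to compound 1 is within the scatter, while compound 2 sits at a lower number beyond the scatter.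

For the measured compounds named here, the only single-point step measured so far is a 2.1-fold higher number from compound 2 to compound 3 (0.33 log units; beyond the scatter), a modest move to a weaker number on exchanging the thiazolyl for the cyanomethylpyrazolyl group.

Compound 4 `Cc1ccc(CNC(=O)c2cccc(C(C)Oc3cccnc3Nc3nncs3)c2)cc1` carries the change (1,3,4-thiadiazol-2-yl in place of 1-(cyanomethyl)-1H-pyrazol-4-yl on a nitrogen on an aromatic ring). The entering 1,3,4-thiadiazol-2-yl is a five-membered aromatic ring with three hetero atoms, closer in kind to the 1,3-thiazol-2-yl of compound 2 than to the cyanomethyl-substituted pyrazole it replaces, so the step measured from compound 2 to compound 3 is the one that bears on it, read in reverse. A modest move back toward a lower number is expected, about a 1.9-fold lower number from compound 3 to compound 4 (0.28 log units; within the scatter), though no thiadiazole has been measured here and the step could also fall within the scatter. Compound 4 is accordingly estimated at 30000 nM in this assay, with a range of 12000 nM to 80000 nM.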

Compound 4, half-maximal inhibitory concentration: 17600 nM
The estimate for compound 4 lay 1.7-fold (0.23 log units) above the measured number, and the stated range covers the measured number.
By their numbers in this assay, from the lowest: compounds 4 and 2 (each within the scatter of the next); then compounds 3 and 1 (each within the scatter of the next).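

In this assay, replacing the 1-(cyanomethyl)-1H-pyrazol-4-yl with the 1,3,4-thiadiazol-2-yl on a nitrogen on an aromatic ring gives a 3.3-fold lower number from compound 3 to compound 4 (0.51 log units; beyond the scatter) and so shows that this position responds to a second sulfur-bearing ring as well as to the 1,3-thiazol-2-yl. Among the compounds shown here, the exchange of the two sulfur-bearing rings gives a 1.5-fold lower number from compound 2 to compound 4 (0.19 log units; within the scatter) and so does not separate them: among compound 2, compound 3 and compound 4, which differ from one another only at this nitrogen, both sulfur-bearing rings stand apart from the cyanomethylpyrazole, with no compound here going against that. Nothing available explains the gap between the sulfur-bearing rings and the cyanomethylpyrazole.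

On these data alone, whether the ring, its sulfur or the cyanomethyl chain drives that gap stays open, since compound 1 carries a methylpyrazole but also differs in its methoxy-bearing benzyl group and so gives no one-place comparison. A 1,3,4-oxadiazol-2-yl, with oxygen in place of the sulfur, or a plain phenyl on the same nitrogen would be the next groups to read against compound 4 in this assay.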